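Swapping the Dibromophenyl Amide for a Bromohydroxyphenyl

The source may hold more compounds than are shown below. What is called first, only, known or untested is meant among the compounds shown, and "the series" means these compounds.

Compound 1 `O=C(Nc1ccc(Sc2nc3ccccc3s2)cc1)c1cc(Br)cc(Br)c1` was tested in an ADME assay on HEK293 cells (Homo sapiens) for cytotoxicity, read by reporter gene assay and resazurin assay, with a stated time of 48 h; a higher number here means that more compound is tolerated, a lower number that less compound is tolerated. In this assay compound 1 gives > 100000 nM, which is a limit of the assay and not a number. Compound 2 `COc1c(Br)cc(Br)cc1C(=O)Nc1ccc(Sc2nc3ccccc3s2)cc1` likewise gives > 100000 nM, also a limit. The step that the two limits leave unreadable from compound 1 to compound 2 therefore cannot be read, since both values sit at the limit of > 100000 nM in this assay, at which 2 of the 2 values shown sit. Compound 3 `O=C(Nc1ccc(Sc2nc3ccccc3s2)cc1)c1cc(Br)ccc1O` carries the change (5-bromo-2-hydroxyphenyl in place of 3,5-dibromophenyl on a carbonyl carbon). Among the compounds with values here, no measured step covers this exchange, and the single step available has no readable size. Compound 3 is expected to remain at the limit, with an estimated 100000 nM (range 40000 nM to 250000 nM). This estimate implies an expected step of a number no higher from compound 1 to compound 3 (the limit leaves the size open).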

Compound 3, half-maximal cytotoxic concentration: 42000 nM
For compound 3 the middle estimate is 2.4-fold (0.38 log units) above the measured one; low and high end bracket the measured number.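

The exchange of 3,5-dibromophenyl for 5-bromo-2-hydroxyphenyl on the carbonyl carbon gives an at least 2.3-fold lower number from compound 1 to compound 3 (0.37 log units; beyond the scatter) in this assay. A change at this place can therefore bring a readable number, which the earlier step to compound 2, unreadable between two limits, could not show. Compound 3 is the only one of the three compounds not at the limit: the limit of > 100000 nM in this assay, at which 2 of the 3 values shown sit.

The exchange alters bromine and hydroxy together, and the compounds shown do not separate the two. As far as these compounds go, how an amine or a carboxylic acid at this place would fare in this assay stays open.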